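The source may hold more compounds than are shown below. What is called first, only, known or untested is meant among the compounds shown, and "the series" means these compounds.

Measured compounds:

Compound 1, `CC(C)Oc1ccccc1N1CCN(CCN(C)C(=O)CN2CCCCC2=O)CC1`: 53 nM
Compound 2, `COc1ccccc1N1CCN(CCCNC(=O)CN2CCCCC2=O)CC1`: 98 nM
Compound 3, `O=C(CN1CCCCC1=O)NCCN1CCN(c2ccc(F)cc2OCC(F)(F)F)CC1`: 129 nM

Of the compounds shown here, three share a core and have been tested in an assay on COS cells for binding affinity to Alpha-1A adrenergic receptor (Homo sapiens); a higher number here means a weaker inhibitor, a lower number a stronger inhibitor. Compound 2, with the structure `COc1ccccc1N1CCN(CCCNC(=O)CN2CCCCC2=O)CC1`, gives 98 nM in this assay. Its number is the second highest of the three, and both neighbours are close: compound 3 gives 129 nM, and compound 1 gives 53 nM. Each of those gaps is within the scatter of repeated measurements, so on these numbers compound 2 cannot be told apart from either of the other two.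

Compound 4, with the structure `CC(C)Oc1ccccc1N1CCN(CCCNC(=O)CN2CCCCC2=O)CC1`, has not yet been measured. It differs from compound 2 in one place: isopropyl in place of methyl on an oxygen on an aromatic ring. Among the measured compounds shown here, no pair of measured compounds differs only in this way, so there is no measured step to lean on. Compound 1 also carries an isopropoxy group, but it differs from compound 4 elsewhere as well, so its value only hints that such compounds can fall in the same region.

The expected step from compound 2 to compound 4 is a 1.4-fold lower number from compound 2 to compound 4 (0.15 log units; within the scatter), a change that is not expected to go beyond the scatter. Compound 4 is estimated to give 70 nM, with a range from 25 nM to 200 nM.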

Compound 4, inhibition constant: 0.66 nM
For compound 4 the middle estimate is 110-fold (2.03 log units) above the measured one, and the stated range ends above it.
By their numbers in this assay, from the lowest: compound 4; then compounds 1, 2 and 3 (each within the scatter of the next, the first and the last beyond it).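

In this assay the change from methoxy to isopropoxy amounts to a 150-fold lower number from compound 2 to compound 4 (2.17 log units; beyond the scatter) and lies far beyond the scatter. This makes the group on this oxygen a sensitive point in the series, something the three earlier compounds, all within the scatter of their nearest neighbours, could not reveal. It also shows that swapping methyl for isopropyl, which adds no ring, no hydrogen-bond donor or acceptor and no charge, can still shift the number sharply, though nothing available here explains why.

The compounds shown leave open how the number responds to other groups on this oxygen, such as ethyl, cyclopropyl or tert-butyl. They also leave open whether the same swap has a similar effect when the shared core carries a different chain.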